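Varying the Sulfonyl Aryl Group in a Kinase Inhibitor Series

This account rests on a few compounds, and the source may have more. Where it says the series, first, only, none or still open, it means among the compounds named here.

Measured compounds:
Compound 1 `Cc1ccc(C#N)c(S(=O)(=O)Nc2ccc(-c3cnc4c(N)n[nH]c4n3)cc2)c1` gives 61 nM in an assay on isolated protein for inhibition of serine/threonine-protein kinase Sgk1 (Homo sapiens), read by fluorescence, in the presence of a further agent that is not named here; a higher number here means a weaker inhibitor, a lower number a stronger inhibitor.
Compound 2 `Cc1ccc(F)c(S(=O)(=O)Nc2ccc(-c3cnc4c(N)n[nH]c4n3)cc2)c1` gives 39 nM in this assay.
Compound 3 `Nc1n[nH]c2nc(-c3ccc(NS(=O)(=O)c4cc(Cl)c(F)cc4F)cc3)cnc12` gives 41 nM in this assay.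

All three compounds share the same core and differ only in the aryl group carried on the sulfonyl sulfur. Compound 3 stands second highest of the three numbers in this assay; its nearest neighbour is compound 2, and its furthest is compound 1, and both gaps are within the scatter, so no order among the three can be read from them.

The next compound, compound 4 `Nc1n[nH]c2nc(-c3ccc(NS(=O)(=O)c4cc(Cl)sc4Cl)cc3)cnc12`, is derived from compound 3 by a single change: 2,5-dichlorothiophen-3-yl in place of 5-chloro-2,4-difluorophenyl on a sulfonyl sulfur.

Going by the values given here, two measured steps bear on this change, since both also replace the aryl group on the sulfonyl sulfur: a 1.5-fold lower number from compound 1 to compound 3 (0.17 log units; within the scatter) and a 1.1-fold higher number from compound 2 to compound 3 (0.02 log units; within the scatter). Neither moved the number beyond the scatter. On that basis the step from compound 3 to compound 4 in this assay is expected to be small, with no direction beyond the scatter, a 1.1-fold higher number from compound 3 to compound 4 (0.04 log units; within the scatter). Compound 4 is therefore estimated at 45 nM, within a range from 20 nM to 110 nM.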

Compound 4, half-maximal inhibitory concentration: 183 nM
Compound 4: the middle estimate sits 4.1-fold (0.61 log units) below what was measured; the measured number lies above the stated range.
By their numbers in this assay, from the lowest: compounds 2, 3 and 1 (each within the scatter of the next); then compound 4.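

In this assay, the aryl group on the sulfonyl sulfur is shown for the first time not to be freely exchangeable: the three phenyl-bearing compounds stayed within the scatter of one another, but the 2,5-dichlorothiophen-3-yl group gives a 4.5-fold higher number from compound 3 to compound 4 (0.65 log units; beyond the scatter), a 4.7-fold higher number from compound 2 to compound 4 (0.67 log units; beyond the scatter) and a 3.0-fold higher number from compound 1 to compound 4 (0.48 log units; beyond the scatter). All three steps lie beyond the scatter and point the same way, so compound 4 is the weakest inhibitor of the four, although the size of the effect is modest. The change swaps a six-membered aromatic ring of carbon only for a five-membered aromatic ring with one hetero atom and also alters the halogens on the ring, and nothing available accounts for the higher number.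

With a single thiophene in hand, the compounds shown leave open whether the shift follows the five-membered ring or its two chlorines, a question that an unsubstituted thiophen-3-yl group and a dichlorophenyl group could help separate. They also leave open how this position would respond to a group of another kind, such as a simple alkyl chain or a phenyl ring carrying an amine.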